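A few compounds are considered here, and "the series" means these few. Any claim that something is new, unique, unknown or untested is made for them only; others in the source may bear on it.

Three small ring compounds carrying an acid group and ring hydroxyls have been tested in an assay for inhibition of alpha-N-acetylgalactosaminidase (Gallus gallus), tested at 1000 uM; a lower number here means less inhibition, a higher number more inhibition at the concentration tested (going by the name of the read-out). Compound 1 `O=C(O)[C@@H]1NCC=C[C@H]1O` gives 3.2%, while its mirror image, compound 3 `O=C(O)[C@H]1NCC=C[C@@H]1O`, gives 25%. The step of a number 21.8 percentage points higher from compound 1 to compound 3 (beyond the scatter) rests on the fact that compounds 1 and 3 differ only in the configuration as drawn: nothing but the drawn configuration changes between the two.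

Compound 2 `O=C(O)[C@H]1NC[C@@H](O)[C@@H](O)[C@@H]1O` is the fully saturated member of the set and gives 3.8% in this assay. That number stands second highest of the three, within the scatter of compound 1 and well below compound 3.

Compound 4 `O=C(O)[C@@H]1NC[C@H](O)[C@H](O)[C@H]1O` is the mirror image of compound 2; the difference is the two compounds have the same atoms and bonds and differ only in configuration as drawn: 4 of 4 stereo elements differ (all stereocentres are inverted: mirror images); a stereocentre at a saturated ring carbon is drawn S in compound 2 and R in compound 4; a stereocentre at a saturated ring carbon is drawn R in compound 2 and S in compound 4; a stereocentre at a saturated ring carbon is drawn R in compound 2 and S in compound 4; a stereocentre at a saturated ring carbon is drawn R in compound 2 and S in compound 4. Among the compounds with values here, the only measured step of the same kind is the mirror-image pair of compounds 1 and 3, where inversion raised inhibition by a modest amount. On that basis a step of a number 14.2 percentage points higher from compound 2 to compound 4 (beyond the scatter) is expected, upward and beyond the scatter. Compound 4 is therefore estimated to give 18%, with a plausible range from 3% to 40%, before its measurement is known.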

Compound 4, a percentage reported as inhibition, at one concentration (the size of the read-out at that concentration, not a potency): 4.4%
Estimate against measurement, compound 4: 13.6 percentage points above; the measured number falls inside the stated range.
By their numbers in this assay, from the lowest: compounds 1, 2 and 4 (each within the scatter of the next); then compound 3.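

The mirror-image step does not carry over from one pair to the other: in this assay the saturated pair gives a number 0.6 percentage points higher from compound 2 to compound 4 (within the scatter), whereas the unsaturated pair gave a number 21.8 percentage points higher from compound 1 to compound 3 (beyond the scatter). Inverting every stereocentre therefore does not by itself move the number beyond the scatter, and of the two mirror-image pairs only compound 1 and compound 3 separate. The change in the new pair is purely one of drawn configuration: the fact that compounds 2 and 4 differ only in the configuration as drawn

The two pairs differ from each other in more than one place, so the compounds shown cannot tell which structural difference makes configuration matter in one pair and not in the other. They also leave open how the number would respond if a methyl ester or an amide replaced the carboxylic acid.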